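Nitro substitution on two related cores

A few compounds are considered here, and "the series" means these few. Any claim that something is new, unique, unknown or untested is made for them only; others in the source may bear on it.

Measured so far in this series:
compound 1 `COc1ccc(-c2ssc(=S)c2-c2cc(OC)c(OC)c(OC)c2)cc1` — 4910 nM
compound 2 `COc1ccc(-c2ssc(=S)c2-c2cc(OC)c(OC)c(OC)c2)cc1[N+](=O)[O-]` — > 100000 nM
compound 3 `COc1ccc(-c2c(-c3cc(OC)c(OC)c(OC)c3)ssc2=O)cc1` — > 100000 nM

In a functional assay on KB cells (Homo sapiens) for antiproliferative activity, read by MTT assay, with a stated time of 72 h (on this read-out higher numbers stand for weaker inhibition and lower numbers for stronger inhibition), compound 1 gives 4910 nM. Compound 2 is reported only as a limit of the assay, > 100000 nM. The step of an at least 20-fold higher number from compound 1 to compound 2 (1.30 log units; beyond the scatter) follows the change (nitro in place of hydrogen on an aromatic carbon). Compound 3 likewise stands at a limit, > 100000 nM. Two of the three values therefore sit at the same point, as summarised by the limit of > 100000 nM in this assay, at which 2 of the 3 values shown sit. How the core of compound 1 and the core of compound 3 differ is not broken down here.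

Compound 4 `COc1ccc(-c2c(-c3cc(OC)c(OC)c(OC)c3)ssc2=O)cc1[N+](=O)[O-]` is not yet measured. It differs from compound 3 by nitro in place of hydrogen on an aromatic carbon, the same change that separates compound 1 from compound 2. Compound 4 is expected to remain at the limit because compound 3 already gives > 100000 nM and the same change produced an at least 20-fold higher number from compound 1 to compound 2 (1.30 log units; beyond the scatter). The expected step is a step that the limit leaves unreadable from compound 3 to compound 4. The estimate for compound 4 in this assay is 200000 nM, with a range from 60000 nM to 600000 nM.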

Compound 4, half-maximal inhibitory concentration: > 100000 nM
Compound 4: only a limit was reported (the forecaster's own chance of this, stated with the estimate: 90%); the middle value lies beyond the limit too.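

In this assay compound 3 and compound 4 are both reported only as limits, so no step between them can be read: the limit of > 100000 nM in this assay, at which 3 of the 4 values shown sit.

The compounds shown leave open whether nitro in place of hydrogen changes anything on the core of compound 3, and how far beyond the limit either compound lies.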